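A few compounds are considered here, and "the series" means these few. Any claim that something is new, unique, unknown or untested is made for them only; others in the source may bear on it.

Working notes on the series in an assay for inhibition of Tryptophan 2,3-dioxygenase (Homo sapiens), with stated times of 10 min and 60 min, tested at 10 uM; a lower number here means a weaker effect, a higher number a stronger effect of the compound at the concentration tested. Compound 1 `O=[N+]([O-])c1ccc(CNc2cc(C(F)(F)F)cc3[nH]ncc23)cc1` gives 47%. Compound 2 `O=[N+]([O-])c1ccccc1CNc1cc(C(F)(F)F)cc2[nH]ncc12` gives 89%. Compound 3 `O=[N+]([O-])c1ccccc1CNc1cc(Br)cc2[nH]ncc12` gives 52%. Compound 3 thus stands second highest of the three numbers: its nearest neighbour is compound 1, within the scatter, and its furthest is compound 2, beyond the scatter. Among the measured compounds shown here, the only measured step between compounds that differ in one place is a number 37 percentage points lower from compound 2 to compound 3 (beyond the scatter), a large drop.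

Compound 4 `O=[N+]([O-])c1ccc(O)cc1CNc1cc(Br)cc2[nH]ncc12` has not yet been measured in this assay. Relative to compound 3 the change is hydroxy in place of hydrogen on an aromatic carbon. For the measured compounds named here, no measured step puts hydroxy in place of hydrogen; the single step available, a number 37 percentage points lower from compound 2 to compound 3 (beyond the scatter), concerns bromo in place of trifluoromethyl and does not bear on this change. The series therefore gives no direction for compound 4, and no step beyond the scatter is expected. For compound 4 the expected step is a number 2 percentage points lower from compound 3 to compound 4 (within the scatter). Compound 4 is estimated at 50%, with a range from 30% to 70%.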

Compound 4, a percentage reported as inhibition, at one concentration (the size of the read-out at that concentration, not a potency): 96%
Compound 4: the middle estimate sits 46 percentage points below what was measured, and the stated range ends below it.
By their numbers in this assay, from the lowest: compounds 1 and 3 (each within the scatter of the next); then compounds 2 and 4 (each within the scatter of the next).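

In this assay, hydroxy in place of hydrogen on an aromatic carbon, para to a nitro group and meta to a large group, gives a number 44 percentage points higher from compound 3 to compound 4 (beyond the scatter) with the bromo group kept in place. Among the compounds shown here, the only earlier step, a number 37 percentage points lower from compound 2 to compound 3 (beyond the scatter), concerned the group on the shared core, so this result is the first to show that a single added hydroxy on the six-membered aromatic ring of carbon only can also shift the read-out by a large amount, and upward. Nothing measured here accounts for the size of this step.

The compounds shown leave open whether the rise needs hydroxy itself or would also come with methoxy, an amine or fluorine on the same carbon. They also leave open whether hydroxy there gives a similar step when trifluoromethyl replaces bromo on the core.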